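The source may report more compounds than this note shows. Statements on the series, on what has been measured and on what is new or still open speak of the compounds shown alone.

Measured compounds: compound 1 `Cc1c(CN2CCCC2)cc(-c2ccccc2)n1Nc1ccnc2cc(Cl)ccc12` with 3880 nM; compound 2 `Cc1c(CN2CCCC2)cc(-c2ccc(Cl)cc2)n1Nc1ccnc2cc(Cl)ccc12` with 2060 nM; compound 3 `CCN(CC)Cc1cc(-c2ccc(C)cc2)n(Nc2ccnc3cc(Cl)ccc23)c1C` with 3650 nM, all in an ADME assay on WEHI13 cells (Mus musculus) for cytotoxicity, read by MTT assay, with a stated time of 72 h; on this read-out lower numbers stand for higher toxicity in this test and higher numbers for lower toxicity in this test.

Compound 3 holds the second highest of the three numbers; its nearest neighbour is compound 1 and its furthest is compound 2, both gaps within the scatter. Within the data shown here, the only step measured, a 1.9-fold lower number from compound 1 to compound 2 (0.27 log units; within the scatter), concerns a different position. Compound 4 `Cc1ccc(-c2cc(CN3CCCC3)c(C)n2Nc2ccnc3cc(Cl)ccc23)cc1` arises from compound 3 by pyrrolidin-1-yl in place of diethylamino on a saturated chain carbon bound to an aromatic carbon. Among the measured compounds shown here, no measured pair shows this exchange of amine, so nothing bears directly on it, and the expectation is a step of a 1.0-fold lower number from compound 3 to compound 4 (0.02 log units; within the scatter), no change beyond the scatter. Compound 4 is therefore estimated at 3500 nM, with a range from 1500 nM to 8000 nM.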

Compound 4, half-maximal cytotoxic concentration: 4480 nM
Compound 4: the middle estimate sits 1.3-fold (0.11 log units) below what was measured, and the stated range covers the measured number.
By their numbers in this assay, from the lowest: compounds 2, 3, 1 and 4 (each within the scatter of the next, the first and the last beyond it).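

The exchange of diethylamino for pyrrolidin-1-yl on this saturated chain carbon, now measured directly in this assay, stays within the scatter (a 1.2-fold higher number from compound 3 to compound 4 (0.09 log units; within the scatter)). Among these compounds, on the aromatic carbon, methyl in place of chloro gives the only step here beyond the scatter (a 2.2-fold higher number from compound 2 to compound 4 (0.34 log units; beyond the scatter)), while methyl in place of hydrogen does not leave it (a 1.2-fold higher number from compound 1 to compound 4 (0.06 log units; within the scatter)). Nothing available explains these steps. The compounds shown leave open whether piperidin-1-yl or morpholin-4-yl at this place would also stay within the scatter. They also leave open how methoxy or fluoro on that aromatic carbon would compare with methyl and chloro.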